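The source may hold more compounds than are shown below. What is called first, only, known or untested is meant among the compounds shown, and "the series" means these compounds.

Measured so far in a functional assay on B16-F10 cells (Mus musculus) for antiproliferative activity, read by MTT assay, with a stated time of 48 h; on this read-out higher numbers stand for weaker inhibition and lower numbers for stronger inhibition:
Compound 1 `COc1cccc(N2CCN(C(=O)/C=C/c3ccc(O)c(O)c3)CC2)c1`: 1.46 ug/mL
Compound 2 `COc1ccc(N2CCN(C(=O)/C=C/c3ccc(O)c(O)c3)CC2)cc1`: 1.21 ug/mL
Compound 3 `O=C(/C=C/c1ccc(O)c(O)c1)N1CCN(c2cccc(C(F)(F)F)c2)CC1`: 2.01 ug/mL

Compound 1 stands among close neighbours in this assay, and neither measured step away from it leaves the scatter. Moving the methoxy group gave a 1.2-fold lower number from compound 1 to compound 2 (0.08 log units; within the scatter), and trifluoromethyl in place of methoxy gave a 1.4-fold higher number from compound 1 to compound 3 (0.14 log units; within the scatter).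

Compound 4 `O=C(/C=C/c1ccc(O)c(O)c1)N1CCN(c2ccc(Cl)c(Cl)c2)CC1` carries 3,4-dichlorophenyl in place of 3-methoxyphenyl on an amine nitrogen in a ring of the shared core: 3,4-dichlorophenyl in place of 3-methoxyphenyl on an amine nitrogen in a ring. Both measured steps bear on this change, and given their size, no step beyond the scatter is expected. The expected change is a 1.2-fold higher number from compound 1 to compound 4 (0.09 log units; within the scatter). For compound 4 the estimated value is 1.8 ug/mL, with an expected range from 0.9 ug/mL to 3.5 ug/mL.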

Compound 4, half-maximal inhibitory concentration: 1.66 ug/mL
Compound 4: the middle estimate sits 1.1-fold (0.04 log units) above what was measured; the measured number falls inside the stated range.
By their numbers in this assay, from the lowest: compounds 2, 1, 4 and 3 (each within the scatter of the next).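

In this assay 3,4-dichlorophenyl on the amine nitrogen gives a 1.1-fold higher number from compound 1 to compound 4 (0.06 log units; within the scatter) and a 1.4-fold higher number from compound 2 to compound 4 (0.14 log units; within the scatter). This extends the flat picture to a group with two chlorine atoms and no hydrogen-bond acceptor: losing the methoxy oxygen produces no step beyond the scatter from either methoxyphenyl compound. No supporting measurement is available to explain this result. The compounds shown leave open whether an amine or a carboxylic acid on this aromatic ring would stay within the scatter. They also leave open whether a longer alkyl chain on this nitrogen, in place of the aromatic ring, would do so.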